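The source may report more compounds than this note shows. Statements on the series, on what has been measured and on what is new or still open speak of the compounds shown alone.

Measured in an ADME assay on HepG2 cells (Homo sapiens) for cytotoxicity, read by neutral red uptake, with a stated time of 48 h; on this read-out higher numbers stand for weaker inhibition and lower numbers for stronger inhibition:
- compound 1 `Cc1cc(NCCCCCCNc2ccnc3cc(Cl)ccc23)nc(N2CCN(C)CC2)n1`: 6300 nM
- compound 2 `Cc1cc(NCCCNc2ccnc3cc(Cl)ccc23)nc(N2CCN(C)CC2)n1`: 26700 nM

Compound 1 holds the lower of the two numbers, and the gap to compound 2 lies beyond the scatter. Compound 3 `Cc1cc(NCCCCCCNc2ccnc3cc(Cl)ccc23)nc(N2CCCCC2)n1` differs from compound 1 in one place: piperidin-1-yl in place of 4-methylpiperazin-1-yl on an aromatic carbon. Going by the values given here, no measured pair shows this change, so the expectation in this assay has no direct precedent: no step beyond the scatter, with a slight lean towards a lower number. The estimated step is a 1.3-fold lower number from compound 1 to compound 3 (0.10 log units; within the scatter). For compound 3 the expected value is 5000 nM, with an estimated range of 2000 nM to 13000 nM.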

Compound 3, half-maximal inhibitory concentration: 6400 nM
Estimate against measurement, compound 3: 1.3-fold (0.11 log units) below; low and high end bracket the measured number.
By their numbers in this assay, from the lowest: compounds 1 and 3 (each within the scatter of the next); then compound 2.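

In this assay, piperidin-1-yl in place of 4-methylpiperazin-1-yl on the aromatic carbon between two ring nitrogen atoms gives a 1.0-fold higher number from compound 1 to compound 3 (0.01 log units; within the scatter). At this position, a ring with one hetero atom and one hydrogen-bond acceptor therefore reads the same as a ring with two of each, on the chain of compound 1. Nothing at hand gives a reason for this result.

Going by these compounds, whether this holds on the chain of compound 2 remains open. So does the reading of a morpholin-4-yl ring or an open-chain dimethylamino group at this position.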